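The compounds below may be only part of what the source reports. "The series", "measured", "known", "first", "only" and "open" are said of these compounds alone.

Measured so far in an assay on isolated protein for binding affinity to Alpha-1A adrenergic receptor (Rattus norvegicus), read by radioligand binding; on this read-out higher numbers stand for weaker inhibition and lower numbers for stronger inhibition:
compound 1, `CS(=O)(=O)Nc1ccc(F)c2c1CCCC2c1c[nH]cn1`, with 309 nM
compound 2, `CCS(=O)(=O)Nc1cccc(-c2c[nH]cn2)c1`, with < 10000 nM

In this assay compound 1 gives 309 nM. Compound 2 stands at the limit of < 10000 nM in this assay, at which 1 of the 2 values shown sits, which is a limit of the assay and not a number, so compound 2 has no fixed place on the scale and only an upper bound on its binding. Within the data shown here, compound 1 and compound 2 differ in more than one place, so no single step between measured compounds is available, and nothing in the data anchors the size or direction of any one change.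

Compound 3, `CCS(=O)(=O)Nc1cccc(C2CCNC2)c1`, is still to be measured in this assay. It differs from compound 2 in one place: pyrrolidin-3-yl in place of 1H-imidazol-4-yl on an aromatic carbon. Because compound 2 sits at the limit of < 10000 nM in this assay, at which 1 of the 2 values shown sits, the step from it can be judged only against a bound, not against a number. The expected step is a step that the limit leaves unreadable from compound 2 to compound 3, set wide since the starting point is itself uncertain. Compound 3 is estimated at 5000 nM, within a range from 500 nM to 30000 nM, with a real chance that this assay again reports only a limit.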

Compound 3, inhibition constant: 501 nM
Estimate against measurement, compound 3: 10-fold (1.00 log units) above; measured number inside the range.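

The step from compound 2 to compound 3 cannot be read, since compound 2 carries a limit and not a number: the limit of < 10000 nM in this assay, at which 1 of the 3 values shown sits.

The compounds shown leave open how large the change is, and in which direction it runs, when pyrrolidin-3-yl stands in place of 1H-imidazol-4-yl on an aromatic carbon.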